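The source may hold more compounds than are shown below. What is called first, only, known or untested is meant among the compounds shown, and "the series" means these compounds.

Working notes on the series built on the shared core of compound 1 (`CC(C)n1ncc2c(NC(=O)c3ccc(F)cc3)cc(-c3cccs3)nc21`). Cytotoxicity is followed in an ADME assay on LLC-MK2 cells (Macaca mulatta) for cytotoxicity, read by spectrophotometry and crystal violet staining, with a stated time of 4 days; a lower number here means that less compound is tolerated, a higher number that more compound is tolerated. In this assay compound 1 gives 50000 nM, and compound 3 (`CC(C)n1ncc2c(C(=O)Nc3cc(S(N)(=O)=O)ccc3F)cc(-c3cccs3)nc21`) gives 25000 nM. Compound 2 (`CC(C)n1ncc2c(C(=O)Nc3ccc(F)cc3F)cc(-c3cccs3)nc21`) reaches only a limit in this assay, > 200000 nM, so no number is known for it. That limit is the limit of > 200000 nM in this assay, at which 1 of the 3 values shown sits. Compound 2 thus stands at the top of what this assay reports, with its true tolerated concentration not pinned down, while compound 1 and compound 3 sit well inside the measured range.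

Compound 4 (`CC(C)n1ncc2c(C(=O)Nc3cccc(F)c3F)cc(-c3cccs3)nc21`) differs from compound 2 by 2,3-difluorophenyl in place of 2,4-difluorophenyl on an amide-type nitrogen. Going by the values given here, no pair of measured compounds differing in one place is available to size such a change in this assay, so no step beyond the usual scatter is expected in either direction; the two difluorophenyl groups carry the same atoms on the same amide-type nitrogen. Compound 4 is therefore estimated to stay near the limit, with the step of an at least 1.1-fold lower number from compound 2 to compound 4 (0.04 log units; that floor lies within the scatter) meaning no real change. Compound 4 is expected to give about 180000 nM, within 50000 nM to 400000 nM, and a repeat of a limit-only reading is considered the more likely outcome.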

Compound 4, half-maximal cytotoxic concentration: 75000 nM
The estimate for compound 4 lay 2.4-fold (0.38 log units) above the measured number; low and high end bracket the measured number.
By their numbers in this assay, from the lowest: compounds 3, 1 and 4 (each within the scatter of the next, the first and the last beyond it). At a limit, above all of these: compound 2.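

The exchange of 2,4-difluorophenyl for 2,3-difluorophenyl on an amide-type nitrogen, with the same atoms joined differently, gives an at least 2.6-fold lower number from compound 2 to compound 4 (0.42 log units; beyond the scatter) in this assay, so the arrangement of the two fluorines alone is enough to produce a step beyond the scatter. Going by these compounds alone, the size of that step is only a floor because compound 2 carries a limit and not a number: the limit of > 200000 nM in this assay, at which 1 of the 4 values shown sits. The earlier compounds offered no pair differing in one place, so this is the first evidence that the group on this amide-type nitrogen is not indifferent in this assay, although it rests on this single pair and supports no wider pattern.

As far as these compounds go, how far the true step lies beyond its floor stays open, since compound 2 has no number in this assay. Also open, from the compounds shown here alone, is whether a plain phenyl, a methoxyphenyl or an aminophenyl on the same amide-type nitrogen would read like compound 2 or like compound 4, and whether the same exchange gives a comparable step on a different group at the other positions of the shared core.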